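Adding one more methyl to a short side chain

The source may report more compounds than this note shows. Statements on the series, on what has been measured and on what is new or still open speak of the compounds shown alone.

Compound 1 `C[C@H](Nc1ncnc2[nH]cnc12)c1nn(-c2cccnc2)c2cc(F)ccc12` gives > 40000 nM as a limit
Compound 2 `C[C@H](Nc1ncnc2[nH]cnc12)c1nn(-c2cccc(S(C)(=O)=O)c2)c2cc(F)ccc12` gives 20000 nM
Compound 3 `CC[C@H](Nc1ncnc2[nH]cnc12)c1nn(-c2cccnc2)c2cc(F)ccc12` gives 29000 nM

In a functional assay on Bel-7402 cells (Homo sapiens) for inhibition, read by sulforhodamine B assay, with a stated time of 72 h (a higher number here means a weaker inhibitor, a lower number a stronger inhibitor), compound 3 gives 29000 nM and lies within the scatter of compound 2 with 20000 nM as its value. For compound 1 the reading > 40000 nM is only a limit.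

Compound 4 `CC(C)[C@H](Nc1ncnc2[nH]cnc12)c1nn(-c2cccnc2)c2cc(F)ccc12` is still unmeasured. The change from compound 3 is methyl in place of hydrogen on a saturated chain carbon bound to two saturated chain carbons and puts methyl in place of hydrogen on a saturated chain carbon bound to two saturated chain carbons, which turns ethyl into isopropyl. The nearest measured change also puts methyl in place of hydrogen on a saturated chain carbon. No step beyond the scatter is expected in this assay for compound 4 because an at least 1.3-fold lower number from compound 1 to compound 3 (0.13 log units; that floor lies within the scatter) is all that change shows. The step of an at least 2.0-fold lower number from compound 1 to compound 2 (0.30 log units; that floor lies within the scatter) concerns a different group and does not bear here. The expected step is a 1.0-fold lower number from compound 3 to compound 4 (0.02 log units; within the scatter) in size. Compound 4 could also meet the limit of > 40000 nM in this assay, at which 1 of the 3 values shown sits, and report no number. Compound 4 is estimated at 28000 nM with 12000 nM and 60000 nM as the ends of the expected range.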

Compound 4, half-maximal inhibitory concentration: > 40000 nM
Compound 4: no number, only a limit (the forecaster's own chance of this, stated with the estimate: 35%); middle value at least 1.4-fold (0.15 log units) away from the limit.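

Turning ethyl into isopropyl, on a saturated chain carbon bound to two saturated chain carbons, gives an at least 1.3-fold higher number from compound 3 to compound 4 (0.13 log units; that floor lies within the scatter), so in this assay the added methyl brings no readable gain, and how far the true value lies beyond that floor is unknown. Among the compounds carrying pyridin-3-yl, only compound 3, with its ethyl, gives an actual number, and the step from compound 1 to compound 4 cannot be read, as both values are limits. The reading for compound 4 therefore adds little detail: the limit of > 40000 nM in this assay, at which 2 of the 4 values shown sit.

As far as these compounds go, whether a longer chain such as propyl, or a cyclopropyl group, would give a number at this position remains open. So does what ethyl or isopropyl would do alongside the 3-(methylsulfonyl)phenyl group of compound 2.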